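The source may report more compounds than this note shows. Statements on the series, on what has been measured and on what is new or still open speak of the compounds shown alone.

Working notes on the series. For the measured compounds named here, in a functional assay on PC-3 cells (Homo sapiens) for antiproliferative activity, read by MTT assay, with a stated time of 72 h (a higher number here means a weaker inhibitor, a lower number a stronger inhibitor), compound 1 `C=CC(=O)Nc1cc2c(N3CCc4ccccc43)ncnc2cc1O[C@@H]1CCOC1` gives 2710 nM, and compound 2 `C/C=C/C(=O)Nc1cc2c(N3CCc4ccccc43)ncnc2cc1O[C@@H]1CCOC1` gives 5220 nM; the step of a 1.9-fold higher number from compound 1 to compound 2 (0.28 log units; within the scatter) is the only single-point change measured so far. Compound 3 `COc1cc2ncnc(N3CCc4ccccc43)c2cc1NC(=O)/C=C/CN1CCN(C)CC1` gives 9180 nM in this assay, the highest of the three numbers, though its gap to compound 2 is within the scatter, and only its gap to compound 1 lies beyond it. Going by the values given here, compound 2 and compound 3 differ in two places at once, so their values show no single step.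

Compound 4 `CN1CCN(C/C=C/C(=O)Nc2cc3c(N4CCc5ccccc54)ncnc3cc2O[C@@H]2CCOC2)CC1` differs from compound 3 by oxolan-3-yl in place of methyl on an oxygen on an aromatic ring, read one bond further out as methoxy to (oxolan-3-yl)oxy. Among the compounds with values here, no measured step bears on this change: the one step available, from vinyl to prop-1-en-1-yl on the carbonyl carbon, sits on the other side of the shared core and is itself within the scatter. Compounds 1 and 2 already carry the (oxolan-3-yl)oxy group and give numbers of the same order as compound 3. The expectation for compound 4 is therefore a step of a 1.3-fold lower number from compound 3 to compound 4 (0.12 log units; within the scatter) in this assay, not beyond the scatter in either direction. The estimate for compound 4 in this assay is 7000 nM, with a range from 2500 nM to 20000 nM.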

Compound 4, half-maximal inhibitory concentration: 4210 nM
Estimate against measurement, compound 4: 1.7-fold (0.22 log units) above; the range from low to high includes it.
By their numbers in this assay, from the lowest: compounds 1, 4, 2 and 3 (each within the scatter of the next, the first and the last beyond it).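

In this assay, for the compounds shown here, methoxy to (oxolan-3-yl)oxy on an aromatic ring gives a 2.2-fold lower number from compound 3 to compound 4 (0.34 log units; beyond the scatter) as the first step read at this position, and the first single-place step beyond the scatter. With the (oxolan-3-yl)oxy group held fixed, 4-methylpiperazin-1-yl in place of hydrogen on a saturated chain carbon gives a 1.2-fold lower number from compound 2 to compound 4 (0.09 log units; within the scatter) and 3-(4-methylpiperazin-1-yl)prop-1-en-1-yl in place of vinyl on a carbonyl carbon gives a 1.6-fold higher number from compound 1 to compound 4 (0.19 log units; within the scatter) so neither change on the carbonyl carbon side moves the number beyond the scatter. Nothing available bears on what lies behind the step at the oxygen.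

Still open, going by these compounds, is whether the step at the oxygen depends on the oxolan-3-yl ring itself, which an ethyl group, a longer chain or a six-membered oxane ring on that oxygen would help to decide, as would the opposite configuration at the defined stereocentre. Also open, on these data alone, is whether the same change gives a step of similar size where vinyl or prop-1-en-1-yl stands on the carbonyl carbon.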